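Two Inactive Analogues and an Added Methoxymethyl Group

The compounds below may be only part of what the source reports. "The series", "measured", "known", "first", "only" and "open" are said of these compounds alone.

Compound 1, `COCn1c(CC(O)(COCc2ccccc2)COCc2ccccc2)cc(=O)[nH]c1=O`, gives only the assay's limit > 100000 nM in a functional assay on MCF7 cells (Homo sapiens) for antiproliferative activity, read by MTT assay, with a stated time of 72 h; on this read-out lower numbers stand for stronger inhibition and higher numbers for weaker inhibition.
Compound 2, `O=c1cc(CC(COCc2ccccc2)COCc2ccccc2)[nH]c(=O)[nH]1`, likewise gives only the limit > 100000 nM in this assay.

Compound 2 therefore stands at the limit rather than at a number, and both values shown sit there, as noted in the limit of > 100000 nM in this assay, at which 2 of the 2 values shown sit. Compound 3, `COCn1c(CC(COCc2ccccc2)COCc2ccccc2)cc(=O)[nH]c1=O`, differs from compound 2 by methoxymethyl in place of hydrogen on an aromatic nitrogen. No measured step links the two, so the size of this change has to be guessed from what is shown. Compound 1 already carries the methoxymethyl group on the same ring nitrogen together with an extra hydroxyl on its chain, and its value > 100000 nM is also only a limit, which gives no hint of a gain. The expected step from compound 2 to compound 3 is a number no higher from compound 2 to compound 3 (the limit leaves the size open), that is, no change beyond the scatter. Compound 3 is therefore estimated at 100000 nM, within 50000 nM to 300000 nM, most likely reported as a limit again.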

Compound 3, half-maximal inhibitory concentration: > 100000 nM
Compound 3 gave a limit, no number (the forecaster's own chance of this, stated with the estimate: 85%); the middle value sits exactly at the limit.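

Compound 3 gives only a limit, so its steps from compound 2 and from compound 1 cannot be read, because all three compounds sit at the same limit: the limit of > 100000 nM in this assay, at which 3 of the 3 values shown sit.

From the compounds shown here alone, whether methoxymethyl or hydroxy changes the result in this assay at all remains open, as does how far these three compounds actually differ.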